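Azo and imine naphthol sulfonic acids at the thrombopoietin receptor

The compounds below may be only part of what the source reports. "The series", "measured", "known", "first", "only" and "open" are said of these compounds alone.

Measured compounds:
compound 1 `O=S(=O)(O)c1cc(O)c(/N=C/c2c(O)ccc3ccccc23)c2ccccc12`: < 5%
compound 2 `O=C(Nc1c(O)cc(S(=O)(=O)O)c2ccccc12)c1c(O)ccc2ccccc12`: < 5%
compound 3 `Cc1[nH]n(C)c(=O)c1/N=N/c1c(O)cc(S(=O)(=O)O)c2ccccc12`: < 5%

In an assay on BaF3 cells with thrombopoietin receptor (Homo sapiens) as the target, read by a luciferase reporter (a higher number here means a larger maximal response, a lower number a smaller maximal response), compound 3 gives < 5%, which is a limit of the assay and not a number. Compound 1 also sits at a limit with < 5%. Compound 2 likewise sits at a limit with < 5%. Among the measured compounds shown here, nothing in the set rises above (the limit of < 5% in this assay, at which 3 of the 3 values shown sit), so no graded step is available.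

Compound 4 `Cc1[nH]n(-c2ccc(O)cc2)c(=O)c1/N=N/c1c(O)cc(S(=O)(=O)O)c2ccccc12` carries the change (4-hydroxyphenyl in place of methyl on an aromatic nitrogen). For the measured compounds named here, no measured pair shows the effect of such a change, so the expected step in this assay is none beyond the scatter, with the compound most likely remaining at the limit; only a small chance of a measurable response is allowed. Compound 4 is estimated at 5% (range 0% to 25%), which means an expected step of a number no lower from compound 3 to compound 4 (the limit leaves the size open).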

Compound 4, largest response reached (reported as efficacy), in percent of the reference or control that the assay uses: < 5%
Compound 4 was reported as a limit; the forecaster's own chance of this, stated with the estimate: 70%; the middle value sits exactly at the limit.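

No step can be read from compound 3 to compound 4 in this assay, because both values are limits: the limit of < 5% in this assay, at which 4 of the 4 values shown sit.

The compounds shown leave open whether 4-hydroxyphenyl in place of methyl on an aromatic nitrogen alters the maximal response at all.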